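One enantiomer of a racemic propanoic acid antagonist

The compounds below may be only part of what the source reports. "The series", "measured", "known", "first", "only" and "open" are said of these compounds alone.

Compound 1 `CC(C(=O)O)c1nn(Cc2cn3cc(OCC4CC4)c(Cl)cc3n2)c2ccccc2c1=O`: 6 nM
Compound 2 `O=C(O)Cn1nc(Cc2nc3cc(F)c(OCC4CC4)cc3[nH]2)c2ccccc2c1=O`: 18 nM

Both compounds were tested in a functional assay on CHO cells for antagonist activity at sphingosine 1-phosphate receptor 2 (Homo sapiens), read by calcium flux; a higher number here means a weaker inhibitor, a lower number a stronger inhibitor. Compound 1 gives 6 nM, the lower of the two numbers; compound 2 gives 18 nM, and the gap between them lies beyond the scatter. Compound 3 `C[C@@H](C(=O)O)c1nn(Cc2cn3cc(OCC4CC4)c(Cl)cc3n2)c2ccccc2c1=O` has not yet been measured. It differs from compound 1 in this way: the two compounds have the same atoms and bonds; at least one stereo element is drawn with a configuration in one of them and without one in the other: 1 of 1 stereo elements differ; a stereocentre at a saturated chain carbon is drawn without a configuration in compound 1 and R in compound 3. Compound 1 thus represents a mixture of two forms, of which compound 3 is one. Among the compounds with values here, no measured pair here separates such forms, so the size of the step cannot be read from the data. If the drawn form carries the activity of the mixture, compound 3 is expected to give a number near that of compound 1 or somewhat lower; if it does not, a much higher number would be expected. On balance the step from compound 1 to compound 3 is expected to be a 1.5-fold lower number from compound 1 to compound 3 (0.18 log units; within the scatter). For compound 3 the estimate in this assay is 4 nM, within a range from 1.5 nM to 40 nM.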

Compound 3, half-maximal inhibitory concentration: 24 nM
Beside the measured number, compound 3's estimate is 6.0-fold (0.78 log units) below it; the range from low to high includes it.
By their numbers in this assay, from the lowest: compound 1; then compounds 2 and 3 (each within the scatter of the next).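

Drawing the stereocentre at the saturated chain carbon as R does not preserve the activity of the mixture in this assay: a 4.0-fold higher number from compound 1 to compound 3 (0.60 log units; beyond the scatter). Within the data shown here, this is the first sign that configuration at this position matters for this series, and since the single form gives a higher number than the mixture that contains it, the opposite configuration would be expected to hold more of the activity. The step rests on a single difference between the two structures: the fact that one of compounds 1 and 3 is drawn with a defined configuration and the other without, at the place where they differ.

The compounds shown leave open what the form with the opposite configuration gives on its own, so that inference remains indirect. They also leave open whether an ethyl group in place of the methyl on this stereocentre, or a tetrazole in place of the carboxylic acid, would keep the number low.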